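The compounds below may be only part of what the source reports. "The series", "measured", "known", "first", "only" and "open" are said of these compounds alone.

Working notes on the series. In a functional assay on the whole organism (strain Wistar) for inhibition, with Rattus norvegicus as the target, read by paw edema, with a stated time of 3 h, at a dose of 10 mg/kg by the oral route (a higher number here means more inhibition at the dose given (going by the name of the read-out), a lower number less inhibition), compound 1 `Clc1ccc(COc2nnc(COc3ccc(-c4ccccc4)cc3)o2)c(Cl)c1` gives 29.5%, compound 2 `Sc1nnc(COc2ccc(-c3ccccc3)cc2)n1-c1ccc(Br)cc1` gives 31.8%, and compound 3 `CCCCNc1nnc(COc2ccc(-c3ccccc3)cc2)s1` gives 27.3%. Compound 3 stands within the scatter of both compound 1 and compound 2, so the three numbers are not separated in this assay. Compound 4 `Cc1ccc(Nc2nnc(COc3ccc(-c4ccccc4)cc3)s2)c(C)c1` has not yet been measured; it differs from compound 3 only in one place: 2,4-dimethylphenyl in place of butyl on a nitrogen on an aromatic ring. Among the measured compounds shown here, no pair of measured compounds shows this change, so nothing in the numbers points to a direction for it. With the three measured numbers lying together, compound 4 is expected to stay close to compound 3, and the step of a number 2.7 percentage points higher from compound 3 to compound 4 (within the scatter) is estimated to lie within the scatter. Compound 4 is expected to give about 30% in this assay, with a range from 18% to 42%.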

Compound 4, a percentage reported as inhibition, in the whole organism at one dose (the size of the read-out at that dose, not a potency): 56.8%
Beside the measured number, compound 4's estimate is 26.8 percentage points below it; the measured number lies above the stated range.
By their numbers in this assay, from the lowest: compounds 3, 1 and 2 (each within the scatter of the next); then compound 4.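

Among the compounds shown here, replacing butyl with 2,4-dimethylphenyl on a nitrogen on an aromatic ring gives the first step beyond the scatter in this assay, a number 29.5 percentage points higher from compound 3 to compound 4 (beyond the scatter). The earlier compounds shown here, whose numbers lay together, gave no sign that this position could move the read-out so far. Nothing at hand bears on why this change has such an effect. Still open, as far as these compounds go, is whether the rise follows the aromatic ring or its two methyl groups: a plain phenyl or a cyclohexyl on this nitrogen would separate the two.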